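The compounds below may be only part of what the source reports. "The series", "measured", "known", "first", "only" and "open" are said of these compounds alone.

In an ADME assay on HepG2 cells (Homo sapiens) for cytotoxicity, read by luminescence, CellTiter-Glo and ATP content, with a stated time of 72 h (on this read-out higher numbers stand for an effect only at larger amounts of compound and lower numbers for an effect already at smaller amounts), compound 2 `COc1cccc(CNCCCNc2ccnc3cc(C4CCCCC4)ccc23)c1O` gives 1080 nM, the lowest of the three numbers at hand, though its neighbour compound 1 `COc1ccc(-c2ccc3c(NCCCNCc4cccc(OC)c4O)ccnc3c2)cc1` gives 1600 nM, and the two sit within the usual scatter of each other. Compound 3 `COc1ccc(F)cc1CNCCCNc1ccnc2cc(C3CCCCC3)ccc12` gives 2290 nM, and here the gap is modest but real: a 2.1-fold higher number from compound 2 to compound 3 (0.33 log units; beyond the scatter).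

Compound 4 `COc1cccc(CNCCCNc2ccnc3cc(-c4ccc(C(C)(C)C)cc4)ccc23)c1O` differs from compound 2 in one place: 4-(tert-butyl)phenyl in place of cyclohexyl on an aromatic carbon. Among the measured compounds shown here, the measured step that bears on this is the one between compound 1 and compound 2, where an aromatic ring at that same position was exchanged for a cyclohexyl ring and the read-out barely moved: a 1.5-fold lower number from compound 1 to compound 2 (0.17 log units; within the scatter). The step from compound 2 to compound 4 runs back in the other direction, cyclohexyl to an aromatic ring, now carrying a tert-butyl group rather than a methoxy group. The other measured step, from compound 2 to compound 3, concerns a different part of the molecule and says nothing about this position.

On this basis no shift beyond the scatter is expected in this assay, so compound 4 is estimated at 1400 nM, with a likely range from 600 nM to 3500 nM; the expected step is a 1.3-fold higher number from compound 2 to compound 4 (0.11 log units; within the scatter).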

Compound 4, half-maximal effective concentration: 690 nM
Compound 4: the middle estimate sits 2.0-fold (0.31 log units) above what was measured, within the range that was stated.
By their numbers in this assay, from the lowest: compounds 4, 2, 1 and 3 (each within the scatter of the next, the first and the last beyond it).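

Exchanging cyclohexyl for 4-(tert-butyl)phenyl on this aromatic carbon, which brings 10 heavy atoms in place of 6, gives (a 1.6-fold lower number from compound 2 to compound 4 (0.19 log units; within the scatter)) in this assay and so stays inside the usual scatter: this position takes the larger aromatic group with no change that can be told apart from noise. The earlier compounds shown here did not show that the group carried on that aromatic ring can count for something, and tert-butyl in place of methoxy gives (a 2.3-fold lower number from compound 1 to compound 4 (0.37 log units; beyond the scatter)), a modest step but the first at this position to lie beyond the scatter. No measurement at hand gives a reason for this step.

Going by these compounds, this rests on a single pair of compounds, so it remains open whether the step reflects a general trend for groups on that ring or belongs to tert-butyl alone. Also open, on these data alone, are how the read-out responds to an amine or a carboxylic acid on that ring in place of tert-butyl, and whether the step holds in compounds carrying the 5-fluoro-2-methoxyphenyl group of compound 3.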